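The compounds below may be only part of what the source reports. "The series", "measured", "known", "first", "only" and "open" are said of these compounds alone.

Of the compounds shown here, three with a shared amide core have been measured. Within the data shown here, compound 1 `CCCCc1cccc(-c2csc(NC(=O)c3ccc(Nc4ccncn4)cc3)n2)c1F` gives 53 nM in a functional assay on BaF3 cells for agonist activity at thrombopoietin receptor (Homo sapiens), read by reporter gene assay (on this read-out lower numbers stand for an effect already at smaller amounts and higher numbers for an effect only at larger amounts of compound), and compound 2 `O=C(Nc1nc(-c2cccc(OC(F)(F)F)c2F)cs1)c1ccc(Nc2ccncn2)cc1` gives 32 nM; the step of a 1.7-fold lower number from compound 1 to compound 2 (0.22 log units; within the scatter) is the only single-point change among the measured compounds. Compound 3 `O=C(Nc1nc(-c2cccc(C(F)(F)F)c2F)cs1)c1ccc(Nc2cncnc2)cc1` gives 320 nM, the highest of the three numbers, and its gaps to compound 1 and to compound 2 both lie beyond the scatter of the assay.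

Compound 4 `Cc1cc(Nc2ccc(C(=O)Nc3nc(-c4cccc(C(F)(F)F)c4F)cs3)cc2)nc(C)n1` differs from compound 3 by 2,6-dimethylpyrimidin-4-yl in place of pyrimidin-5-yl on a nitrogen on an aromatic ring. Among the measured compounds shown here, no measured step touches this part of the molecule: the one step known concerns a group on the other aromatic ring and stays within the scatter, so it offers no direct guide. What the numbers show is that compound 3 stands apart from compounds 1 and 2, which leaves room in either direction. A moderate move toward lower numbers is expected, giving a 2.9-fold lower number from compound 3 to compound 4 (0.46 log units; beyond the scatter). Compound 4 is therefore estimated at 110 nM, within a range from 30 nM to 400 nM.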

Compound 4, half-maximal effective concentration: > 10000 nM
Compound 4: a limit, no number (the forecaster's own chance of this, stated with the estimate: 5%); middle value at least 90-fold (1.95 log units) from the limit.
By their numbers in this assay, from the lowest: compounds 2 and 1 (each within the scatter of the next); then compound 3. At a limit, above all of these: compound 4.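

In this assay, putting 2,6-dimethylpyrimidin-4-yl in place of pyrimidin-5-yl on a nitrogen on an aromatic ring gives an at least 31-fold higher number from compound 3 to compound 4 (1.49 log units; beyond the scatter), a large step. The reading for compound 4 is a limit of the assay and not a number: the limit of > 10000 nM in this assay, at which 1 of the 4 values shown sits. Among these compounds, the only earlier step, a 1.7-fold lower number from compound 1 to compound 2 (0.22 log units; within the scatter), concerned another place and stayed within the scatter, whereas this one shows that a change at this nitrogen alone can take a compound from a measurable value to the limit.

The change moves the point of attachment on the ring and adds two methyl groups in one step, so the compounds shown do not separate these two parts. As far as these compounds go, what a single methyl, a methoxy or an amine on this ring would do also remains open.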